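This account rests on a few compounds, and the source may have more. Where it says the series, first, only, none or still open, it means among the compounds named here.

Measured so far:

Compound 1, `C#Cc1cn([C@@H]2O[C@H](CO)[C@@H](O)[C@H]2O)c2ncnc(N(C)C)c12`, in a functional assay on HCT-116 cells (Homo sapiens), read by MTT assay, with a stated time of 72 h (on this read-out lower numbers stand for stronger inhibition and higher numbers for weaker inhibition), gives 180 nM.
Compound 2, `Cc1ncnc2c1c(-c1cccs1)cn2[C@@H]1O[C@H](CO)[C@@H](O)[C@H]1O`, in this assay gives only a limit, > 20000 nM.
Compound 3, `CSc1ncnc2c1c(-c1cccs1)cn2[C@@H]1O[C@H](CO)[C@@H](O)[C@H]1O`, in this assay gives only a limit, > 20000 nM.

Compound 3 thus stands at the edge of what this assay can report: its value is a limit, not a number, and it shares that limit with compound 2 (the limit of > 20000 nM in this assay, at which 2 of the 3 values shown sit). Within the data shown here, the one measured step, a step that the two limits leave unreadable from compound 2 to compound 3, is therefore unreadable in size.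

Compound 4, `CN(C)c1ncnc2c1c(-c1cccs1)cn2[C@@H]1O[C@H](CO)[C@@H](O)[C@H]1O`, differs from compound 3 by dimethylamino in place of methylsulfanyl on an aromatic carbon. Among the measured compounds shown here, no measured step carries this very change. What the shown values offer is compound 1, which bears the same dimethylamino group together with an ethynyl group and gives a number well inside the range of this assay, while compound 3, with methylsulfanyl and a thiophene ring, gives only a limit. Whether the dimethylamino group alone moves a thiophene-bearing compound off the limit is not settled by these three values, so the expectation is wide. Compound 4 is expected at 5000 nM, between 500 nM and 20000 nM, an estimated step of an at least 4.0-fold lower number from compound 3 to compound 4 (0.60 log units; beyond the scatter).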

Compound 4, half-maximal inhibitory concentration: > 20000 nM
Compound 4: no number, only a limit (the forecaster's own chance of this, stated with the estimate: 45%); middle value at least 4.0-fold (0.60 log units) away from the limit.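

Among these compounds, with the dimethylamino group kept, thiophen-2-yl in place of ethynyl on an aromatic carbon gives the first readable step in this assay: an at least 110-fold higher number from compound 1 to compound 4 (2.04 log units; beyond the scatter). The dimethylamino group therefore does not by itself bring a thiophen-2-yl compound to a number, as compound 2, compound 3 and compound 4 all remain at the limit. The steps among these three compounds cannot be read because their values are limits rather than numbers: the limit of > 20000 nM in this assay, at which 3 of the 4 values shown sit.

As far as these compounds go, how far beyond the limit these three compounds lie remains unknown, so methyl, methylsulfanyl and dimethylamino cannot be ranked here. Also open, from the compounds shown here alone, is whether the ethynyl group itself is needed for a number, or whether a phenyl ring or a propynyl chain in its place would also give one.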